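The source may report more compounds than this note shows. Statements on the series, on what has been measured and on what is new or still open speak of the compounds shown alone.

Measured in a functional assay on CHO cells with adenosine receptor A1 (Homo sapiens) as the target, read by cAMP accumulation and immunoassay, with a stated time of 6 min, tested at 1 uM; a higher number here means a weaker effect of the compound at the concentration tested, a lower number a stronger effect:

compound 1, `Nc1scc(CN2CCN(c3ccc(F)cc3Cl)CC2)c1C(=O)c1ccc(Cl)cc1`: -39%
compound 2, `Nc1scc(CN2CCN(c3cccc(C(F)(F)F)c3)CC2)c1C(=O)c1ccc(Cl)cc1`: -72%

Compound 2 has the lowest of the two numbers in this assay; its nearest neighbour is compound 1, and the gap between them is beyond the scatter. Among the compounds with values here, the one measured step, a number 33 percentage points lower from compound 1 to compound 2 (beyond the scatter), exchanges the whole aryl group on the piperazine nitrogen and is large.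

Compound 3, `Nc1scc(CN2CCN(c3ccc(Cl)c(C(F)(F)F)c3)CC2)c1C(=O)c1ccc(Cl)cc1`, is not yet measured. It differs from compound 2 by chloro in place of hydrogen on an aromatic carbon. Within the data shown here, no measured pair isolates this single change; the only measured step swaps the entire aryl group rather than adding one substituent to it, so it bears on the present step only loosely. On that basis the expected step from compound 2 to compound 3 in this assay is a number 2 percentage points higher from compound 2 to compound 3 (within the scatter), not beyond the scatter in either direction. For compound 3 the estimated value in this assay is -70%, with a range from -95% to -42%.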

Compound 3, a percentage reported as activity, at one concentration (the size of the read-out at that concentration, not a potency): -47%
The estimate for compound 3 lay 23 percentage points below the measured number; low and high end bracket the measured number.
By their numbers in this assay, from the lowest: compound 2; then compounds 3 and 1 (each within the scatter of the next).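

In this assay the added chloro, on an aromatic carbon ortho to a trifluoromethyl group and para to a large group, gives a number 25 percentage points higher from compound 2 to compound 3 (beyond the scatter) and so shows that this position responds to a single added heavy atom, where the earlier step exchanged the whole aryl group. With a number 8 percentage points lower from compound 1 to compound 3 (within the scatter) as the other new step, compound 3 and compound 1 stand within the scatter of each other, so a trifluoromethyl group on the aryl ring does not by itself go with the low number of compound 2. Nothing measured here accounts for the size of the chloro step.

As far as these compounds go, whether fluoro, methyl, methoxy or an amine on the same carbon would give a step of similar size remains open. Also open, from the compounds shown here alone, is whether chloro has a comparable effect without the neighbouring trifluoromethyl group.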